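This account rests on a few compounds, and the source may have more. Where it says the series, first, only, none or still open, it means among the compounds named here.

The series rests on a shared core carrying a basic side chain and a cinnamoyl amide. Compound 3 `Cc1ccc(C(CCN(C)C)NC(=O)/C=C/c2ccccc2)cc1` gives 97% in a functional assay on NIH3T3 cells for agonist activity at Urotensin-2 receptor (Homo sapiens), with a stated time of 5 days (a lower number here means a smaller maximal response, a higher number a larger maximal response), which is the largest response reached, reported as efficacy, relative to the reference. Compound 1 `COc1ccc(/C=C/C(=O)NC(CCN(C)C)c2ccc(C)cc2)cc1` is its methoxy analogue; in this assay compound 1 gives 79%. The change between them, (methoxy in place of hydrogen on an aromatic carbon), produced a number 18 percentage points lower from compound 3 to compound 1 (beyond the scatter). Compound 2 `CN(C)CCC(NC(=O)/C=C/c1ccccc1)c1ccc2ccccc2c1` has a different core, and how it differs from compound 3 is not broken down here; in this assay compound 2 gives 116%, the highest of the three numbers, with compound 3 the nearest and compound 1 the furthest.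

Compound 4 `COc1ccc(/C=C/C(=O)NC(CCN(C)C)c2ccc3ccccc3c2)cc1` is not yet measured. It differs from compound 2 by methoxy in place of hydrogen on an aromatic carbon, the same change as from compound 3 to compound 1. If the change behaves in the same way on the core of compound 2, a step of about a number 18 percentage points lower from compound 2 to compound 4 (beyond the scatter) is expected, resting on the single earlier step of a number 18 percentage points lower from compound 3 to compound 1 (beyond the scatter). Compound 4 is therefore estimated at 98% in this assay, plausibly between 80% and 116%.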

Compound 4, largest response reached (reported as efficacy), in percent of the reference or control that the assay uses: 106%
Estimate against measurement, compound 4: 8 percentage points below, and the stated range covers the measured number.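

In this assay, the methoxy change on the core of compound 2 produces a number 10 percentage points lower from compound 2 to compound 4 (within the scatter), so on this core the change does not separate the two compounds, whereas on the core of compound 3 it gave a step beyond the scatter. Set side by side, the two steps do not differ, and nothing here indicates that the core alters what the change does: the same change on two cores in this assay, a number 18 percentage points lower (beyond the scatter) from compound 3 to compound 1 and a number 10 percentage points lower (within the scatter) from compound 2 to compound 4, 8 percentage points apart, within the scatter of two such steps. This rests on just two pairs, however, and it shows neither that the step has one fixed size nor that it would carry over to any further core.

The compounds shown leave open whether an ethoxy group, a chlorine atom or a hydroxyl group in place of the methoxy would behave in the same way on these two cores. They also leave open how the change would fare with a longer chain or a primary amine in the side chain.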